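Replacing a nitro group with methoxy on the amide-side ring

A few compounds are considered here, and "the series" means these few. Any claim that something is new, unique, unknown or untested is made for them only; others in the source may bear on it.

Compound 3 `COc1cc2c(Oc3ccc(NC(=O)c4nn(-c5ccc([N+](=O)[O-])cc5)c(=O)c5ccccc45)cc3F)ccnc2cc1OCCCN1CCCCC1` gives 1140 nM in a functional assay on MKN-45 cells (Homo sapiens) for cytotoxicity, read by MTT assay, with a stated time of 72 h (a higher number here means a weaker inhibitor, a lower number a stronger inhibitor), the second highest of three numbers. Compound 2 `COc1cc2c(Oc3ccc(NC(=O)c4nn(-c5ccccc5)c(=O)c5ccccc45)cc3F)ccnc2cc1OCCCN1CCCCC1` gives 590 nM, and compound 1 `COc1ccc(-n2nc(C(=O)Nc3ccc(Oc4ccnc5cc(OCCCN6CCCC6)c(OC)cc45)c(F)c3)c3ccccc3c2=O)cc1` gives 1320 nM; both gaps to compound 3 lie within the scatter. Among the compounds with values here, the only single-change step available, a 1.9-fold higher number from compound 2 to compound 3 (0.29 log units; within the scatter), stays within the scatter. Compound 4 `COc1ccc(-n2nc(C(=O)Nc3ccc(Oc4ccnc5cc(OCCCN6CCCCC6)c(OC)cc45)c(F)c3)c3ccccc3c2=O)cc1` differs from compound 3 by methoxy in place of nitro on an aromatic carbon. Compound 1 bears the same methoxy group on a closely related frame and gives 1320 nM, close to compound 3. The change is therefore expected to give a 1.2-fold lower number from compound 3 to compound 4 (0.08 log units; within the scatter), no shift beyond the scatter. Compound 4 is estimated at 950 nM, within 400 nM to 2200 nM.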

Compound 4, half-maximal inhibitory concentration: 950 nM
For compound 4 middle estimate and measured number coincide at the digits printed; the range from low to high includes it.
By their numbers in this assay, from the lowest: compounds 2, 4, 3 and 1 (each within the scatter of the next, the first and the last beyond it).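

In this assay, 4-methoxyphenyl and 4-nitrophenyl cannot be told apart, with a 1.2-fold lower number from compound 3 to compound 4 (0.08 log units; within the scatter). Methoxy in place of hydrogen on the same ring also gives no clear shift, with a 1.6-fold higher number from compound 2 to compound 4 (0.21 log units; within the scatter), and neither does piperidin-1-yl in place of pyrrolidin-1-yl on the chain, with a 1.4-fold lower number from compound 1 to compound 4 (0.14 log units; within the scatter). Nothing measured here offers an explanation for these results. As far as these compounds go, it remains open whether an amine or a carboxylic acid on this ring would move the number beyond the scatter. The same question stands for a longer chain leading to the piperidin-1-yl group.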